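From compound 2 to its 2-methoxy-2-methylpropyl ether

The compounds below may be only part of what the source reports. "The series", "measured", "known", "first", "only" and "open" are said of these compounds alone.

In a functional assay on HT-29 cells (Homo sapiens) for antiproliferative activity, read by MTT assay, with a stated time of 72 h (a lower number here means a stronger inhibitor, a higher number a weaker inhibitor), compound 2 `O=c1c(-c2ccc(F)cc2)c[nH]c2ccnc(Nc3ccc(Oc4ccnc5cc(O)ccc45)c(F)c3)c12` gives 5900 nM and compound 1 `CC(C)(O)COc1ccc2c(Oc3ccc(Nc4nccc5[nH]cc(-c6ccc(F)cc6)c(=O)c45)cc3F)ccnc2c1` gives 3400 nM, so the two stand within the scatter of each other. Compound 3 `COC(C)(C)COc1ccc2c(Oc3ccc(Nc4nccc5[nH]cc(-c6ccc(F)cc6)c(=O)c45)cc3F)ccnc2c1` carries 2-methoxy-2-methylpropyl in place of hydrogen on an oxygen on an aromatic ring. For the measured compounds named here, the one measured step that bears on this is a 1.7-fold higher number from compound 1 to compound 2 (0.24 log units; within the scatter), where hydrogen replaces 2-hydroxy-2-methylpropyl at that place. No step beyond the scatter is therefore expected, and the estimate is a 1.8-fold lower number from compound 2 to compound 3 (0.25 log units; within the scatter). For compound 3 the expected value is 3300 nM, with an estimated range of 1300 nM to 8000 nM.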

Compound 3, half-maximal inhibitory concentration: 4800 nM
Beside the measured number, compound 3's estimate is 1.5-fold (0.16 log units) below it, and the stated range covers the measured number.
By their numbers in this assay, from the lowest: compounds 1, 3 and 2 (each within the scatter of the next).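

In this assay, 2-methoxy-2-methylpropyl in place of hydrogen on the oxygen on the aromatic ring gives a step within the scatter (a 1.2-fold lower number from compound 2 to compound 3 (0.09 log units; within the scatter)), so this ether, like the 2-hydroxy-2-methylpropyl ether, cannot be told apart from the free hydroxy compound. Methyl in place of hydrogen on the oxygen on a saturated carbon also leaves the number within the scatter (a 1.4-fold higher number from compound 1 to compound 3 (0.15 log units; within the scatter)), so the chain's hydroxy hydrogen shows no readable contribution. No evidence bears on these results. Still open, from the compounds shown here alone, is whether an amine, a carboxylic acid or a longer chain on this oxygen would produce a step beyond the scatter.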